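Stilbene-derived chain esters and nitriles in Jurkat cytotoxicity

The source may hold more compounds than are shown below. What is called first, only, known or untested is meant among the compounds shown, and "the series" means these compounds.

The series was followed in a functional assay on Jurkat cells (Homo sapiens) for cytotoxicity, with a stated time of 72 h; on this read-out higher numbers stand for an effect only at larger amounts of compound and lower numbers for an effect already at smaller amounts. Compound 1 `C=C[C@@](C)(/C=C/c1ccc(O)cc1)CC/C=C/C(=O)OCC` carries an ethoxycarbonyl group on its chain. In this assay compound 1 gives > 49000 nM, a limit of the assay and not a number. Compound 2 `C=C[C@@](C)(/C=C/c1ccc(O)cc1)CC/C=C/C#N` is its nitrile counterpart. In this assay compound 2 gives > 49000 nM, again a limit. Going from compound 2 to compound 1 means (ethoxycarbonyl in place of cyano on a double-bonded chain carbon bound to a double-bonded chain carbon), and the step that the two limits leave unreadable from compound 2 to compound 1 cannot be read because the limit of > 49000 nM in this assay, at which 3 of the 3 values shown sit, holds both ends.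

Compound 3 `COc1ccc(/C=C/[C@@](C)(/C=C/c2ccc(O)c(/C=C/C#N)c2)CCC=C(C)C)cc1` has a larger core; how its core differs from that of compound 2 is not broken down here. In this assay compound 3 gives > 49000 nM, once more a limit. Compound 4 `CCOC(=O)/C=C/c1cc(/C=C/[C@](C)(/C=C/c2ccc(OC)cc2)CCC=C(C)C)ccc1O` is the not yet measured partner of compound 3, and the change is ethoxycarbonyl in place of cyano on a double-bonded chain carbon bound to a double-bonded chain carbon, the same kind of change as that from compound 2 to compound 1 at the same kind of place.

The measured instance of this change gave no readable step because the limit of > 49000 nM in this assay, at which 3 of the 3 values shown sit, caps all three values shown. No effect within the tested range is known for any member of the series, and the change itself has never moved a value off the limit. The step from compound 3 to compound 4 is therefore expected to be a step that the limit leaves unreadable from compound 3 to compound 4, in practice no readable change. Compound 4 is expected to give about 60000 nM in this assay, most probably reported only as a limit. The expected range for compound 4 runs from 20000 nM to 200000 nM.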

Compound 4, half-maximal effective concentration: > 49000 nM
Compound 4 was reported as a limit; the forecaster's own chance of this, stated with the estimate: 85%; the middle value is on the limit's open side.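

No step can be read from compound 3 to compound 4 in this assay, because both compounds stop at the same limit, so neither value is a number: the limit of > 49000 nM in this assay, at which 4 of the 4 values shown sit.

The compounds shown leave open whether ethoxycarbonyl in place of cyano changes the effect at all in this assay, and at what concentration, if any, a member of this series gives an effect.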